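The source may hold more compounds than are shown below. What is called first, only, known or untested is meant among the compounds shown, and "the series" means these compounds.

Compound 1 `CSc1ccc(CNc2nc(SC)nc3ncccc23)cc1` was tested in a functional assay on MCF7 cells (Homo sapiens) for cytotoxicity, read by MTT assay, with a stated time of 72 h (a lower number here means a stronger inhibitor of growth, a higher number a weaker inhibitor of growth), where compound 1 gives 4370 nM. Two further compounds share a different core. Compound 3 `CSc1ccc(CNc2nc([SeH])nc3ccccc23)cc1` gives > 100000 nM in this assay, which is a limit of the assay and not a number (the limit of > 100000 nM in this assay, at which 1 of the 3 values shown sits). Compound 2 `COc1ccc(CNc2nc([SeH])nc3ccccc23)cc1` gives 94000 nM in this assay. From compound 3 to compound 2 the change is methoxy in place of methylsulfanyl on an aromatic carbon, and the step is an at least 1.0-fold lower number from compound 3 to compound 2 (0.02 log units; that floor lies within the scatter). How the core of compound 1 differs from the core of compound 3 is not broken down here; in this assay compound 1 stands lowest of the two numbers given, with compound 2 at a higher number.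

Compound 4 `COc1ccc(CNc2nc(SC)nc3ncccc23)cc1` has not yet been measured in this assay. From compound 1 to compound 4 the change is methoxy in place of methylsulfanyl on an aromatic carbon, the same change as from compound 3 to compound 2. Because that earlier step an at least 1.0-fold lower number from compound 3 to compound 2 (0.02 log units; that floor lies within the scatter) is only a floor that lies within the scatter, compound 4 is expected to sit close to compound 1, with an estimated step of a 1.1-fold higher number from compound 1 to compound 4 (0.06 log units; within the scatter). Compound 4 is therefore estimated at 5000 nM in this assay, expected between 1500 nM and 20000 nM.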

Compound 4, concentration for total growth inhibition: > 100000 nM
Compound 4: only a limit was reported; the forecaster's own chance of this, stated with the estimate: 3%; middle value at least 20-fold (1.30 log units) from the limit.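

Methoxy in place of methylsulfanyl on an aromatic carbon, on the core of compound 1, gives a step of an at least 22-fold higher number from compound 1 to compound 4 (1.35 log units; beyond the scatter) in this assay. Compound 4 gives > 100000 nM, which is a limit of the assay and not a number, so this step is only a floor. Set beside the earlier step, the change does not carry from one core to the other as a step of one size, although a limit at one end of each step leaves the true size of both unknown, and two cores give no rule for any other core: the same change on two cores in this assay, an at least 1.0-fold lower number (0.02 log units; that floor lies within the scatter) from compound 3 to compound 2 and an at least 22-fold higher number (1.35 log units; beyond the scatter) from compound 1 to compound 4, at least 24-fold (1.38 log units) apart, beyond the scatter of two such steps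

The compounds shown leave open how far methoxy and methylsulfanyl truly stand apart on either core, since the values at the limit give no number. They also leave open what an ethoxy group, a longer chain, an amine or a chlorine on that same aromatic carbon would give on each core.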